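The source may report more compounds than this note shows. Statements on the series, on what has been measured and on what is new or still open speak of the compounds shown alone.

In a physicochemical assay for solubility, with a stated time of 3 days, at pH 2 (on this read-out lower numbers stand for lower solubility and higher numbers for higher solubility), compound 1 `COc1ccc(CN2CCC(CCOc3ccc(-c4nc5cc(C(N)=O)ccc5[nH]4)cc3)CC2)cc1` gives > 400000 nM, which is a limit of the assay and not a number. Going by the values given here, compound 2 `NC(=O)c1ccc2[nH]c(-c3ccc(OCCC4CCN(Cc5ccc(Cl)cc5)CC4)cc3)nc2c1` gives 179000 nM, the only true number so far. Compound 3 `NC(=O)c1ccc2[nH]c(-c3ccc(OCCC4CCN(C(=O)c5ccccc5)CC4)cc3)nc2c1` has benzoyl in place of 4-chlorobenzyl on an amine nitrogen in a ring. Among the compounds with values here, the only measured step, an at least 2.2-fold lower number from compound 1 to compound 2 (0.34 log units; beyond the scatter), came with chloro in place of methoxy on an aromatic carbon. That is a different change and so a weak guide, but on it a modest further fall is expected in this assay. Compound 3 is estimated at 80000 nM, with a range from 15000 nM to 350000 nM. The expected change is a 2.2-fold lower number from compound 2 to compound 3 (0.35 log units; beyond the scatter).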

Compound 3, solubility: 3000 nM
Beside the measured number, compound 3's estimate is 27-fold (1.43 log units) above it; the whole stated range lies above it.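

In this assay, the amine nitrogen in the ring proves a far more sensitive place than the change on the aromatic carbon had shown: benzoyl in place of 4-chlorobenzyl gives a 60-fold lower number from compound 2 to compound 3 (1.78 log units; beyond the scatter). Benzoyl in place of 4-methoxybenzyl gives an at least 130-fold lower number from compound 1 to compound 3 (2.12 log units; beyond the scatter). That step starts from compound 1, whose value is a limit and not a number: the limit of > 400000 nM in this assay, at which 1 of the 3 values shown sits.

Benzoyl differs from 4-chlorobenzyl both in its carbonyl and in lacking chlorine, so the two changes remain unseparated. A plain benzyl or a chlorobenzoyl group on the same nitrogen would pull them apart.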